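Methylcarbamoyl to propylcarbamoyl: outlook for compound 3

A few compounds are considered here, and "the series" means these few. Any claim that something is new, unique, unknown or untested is made for them only; others in the source may bear on it.

Working notes on the series. Compound 1 `CNC(=O)c1cc(Oc2ccc(NC(=O)c3cc4cccnc4n(-c4ccc(Br)cc4)c3=O)cc2)ccn1` and compound 2 `CNC(=O)c1cc(Oc2ccc(NC(=O)c3cc4cccnc4n(-c4ccc(F)c(Cl)c4)c3=O)cc2)ccn1` share one core and differ only in the group on the aromatic nitrogen. In a functional assay on A549 cells (Homo sapiens) for antiproliferative activity, read by MTT assay, with a stated time of 72 h (a higher number here means a weaker inhibitor, a lower number a stronger inhibitor), compound 1 gives 1050 nM. In this assay compound 2 gives 1560 nM; the step of a 1.5-fold higher number from compound 1 to compound 2 (0.17 log units; within the scatter) lies within the scatter, so compound 2 stands level with compound 1 and is the nearer of the two only by number.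

Compound 3 `CCCNC(=O)c1cc(Oc2ccc(NC(=O)c3cc4cccnc4n(-c4ccc(F)c(Cl)c4)c3=O)cc2)ccn1` is not yet measured. It differs from compound 2 by ethyl in place of hydrogen on a saturated chain carbon bound to an amide-type nitrogen, read one bond further out as methylcarbamoyl to propylcarbamoyl. Going by the values given here, the single measured step, a 1.5-fold higher number from compound 1 to compound 2 (0.17 log units; within the scatter), concerns the aromatic nitrogen substituent and is within the scatter; no measured step touches the amide chain, so there is no basis for a direction. The expected step is therefore a 1.1-fold higher number from compound 2 to compound 3 (0.04 log units; within the scatter), nothing beyond the scatter. Compound 3 is estimated at 1700 nM in this assay, with a range of 600 nM to 5000 nM.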

Compound 3, half-maximal inhibitory concentration: 590 nM
Compound 3: middle estimate off by 2.9-fold (0.46 log units), on the high side; the measured number lies below the stated range.
By their numbers in this assay, from the lowest: compounds 3, 1 and 2 (each within the scatter of the next, the first and the last beyond it).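

In this assay, going by these compounds alone, the amide chain is the first place where a single change moves the number beyond the scatter: methylcarbamoyl to propylcarbamoyl gives a 2.6-fold lower number from compound 2 to compound 3 (0.42 log units; beyond the scatter) while the only earlier step, a 1.5-fold higher number from compound 1 to compound 2 (0.17 log units; within the scatter) on the aromatic nitrogen, stayed within it. This position therefore accepts ethyl in place of hydrogen on the saturated chain carbon with a modest gain rather than a loss, so the amide chain matters more here than the earlier pair could show. Nothing measured on these compounds explains this gain.

The compounds shown leave open whether the gain continues with a longer chain such as butyl, or holds for a chain ending in an amine or a carboxylic acid. They also leave open whether propylcarbamoyl gives the same step alongside the 4-bromophenyl group of compound 1.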